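Aminotetralin-imidazole series: acetamide removal at the aryl nitrogen

The source may hold more compounds than are shown below. What is called first, only, known or untested is meant among the compounds shown, and "the series" means these compounds.

Measured so far in an assay on isolated protein (Cricetulus griseus) for binding affinity to Alpha-1B adrenergic receptor (Mesocricetus auratus), read by radioligand binding; a higher number here means a weaker inhibitor, a lower number a stronger inhibitor:
compound 1 `O=S(=O)(Nc1cccc2c1CCCC2c1c[nH]cn1)c1ccc2ccccc2c1` gives 214 nM
compound 2 `CC(=O)Nc1cccc2c1CCCC2c1c[nH]cn1` gives < 10000 nM

For compound 2 this reading is a limit of the assay, not a number; it stands at the limit of < 10000 nM in this assay, at which 1 of the 2 values shown sits. Compound 1 has a measured value, and the two cannot be ranked further on what is shown. Compound 3 `Nc1cccc2c1CCCC2c1c[nH]cn1` is not yet measured in this assay. It differs from compound 2 by hydrogen in place of acetyl on a nitrogen on an aromatic ring. No measured step of this kind exists among the shown compounds. The change is expected to stay within the usual scatter, a step that the limit leaves unreadable from compound 2 to compound 3. Compound 3 is expected to give 6000 nM, between 1500 nM and 25000 nM.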

Compound 3, inhibition constant: 525 nM
The estimate for compound 3 lay 11-fold (1.06 log units) above the measured number; the measured number lies below the stated range.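

No step between compound 2 and compound 3 can be read, because the reading for compound 2 is a limit of the assay and not a number: the limit of < 10000 nM in this assay, at which 1 of the 3 values shown sits.

The compounds shown leave open the size of the acetamido to amino change in this assay.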